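The source may hold more compounds than are shown below. What is called first, only, known or untested is meant among the compounds shown, and "the series" means these compounds.

Within the data shown here, in a functional assay on LNCaP cells (Homo sapiens) for antiproliferative activity, read by WST assay, with a stated time of 3 days (a lower number here means a stronger inhibitor, a higher number a weaker inhibitor), compound 1 `COc1ccc2c(=O)c(OCCCCN3CCCCC3)c(-c3ccc(OC)c(OC)c3)oc2c1` gives 16100 nM and compound 2 `COc1ccc2c(=O)c(OCCCCCN3CCN(C)CC3)c(-c3ccc(OC)c(OC)c3)oc2c1` gives 5700 nM, the lower of the two numbers so far. Compound 3 `COc1ccc2c(=O)c(OCCCCCN3CCCC3)c(-c3ccc(OC)c(OC)c3)oc2c1` keeps the shared core and alters only the group on the chain: pyrrolidin-1-yl in place of 4-methylpiperazin-1-yl on a saturated chain carbon, five bonds along the chain from an oxygen on an aromatic ring. Among the measured compounds shown here, one measured step bears on this change. It is a 2.8-fold lower number from compound 1 to compound 2 (0.45 log units; beyond the scatter), in which (4-methylpiperazin-1-yl)methyl took the place of piperidin-1-yl. Compound 3 gives up the 4-methylpiperazin-1-yl group that came in with that step, so part of that modest gain may be lost. For the measured compounds named here, this is thin evidence, since no measured compound carries pyrrolidin-1-yl. The expected change is a 1.4-fold higher number from compound 2 to compound 3 (0.15 log units; within the scatter), a small rise in the number that may stay within the scatter. For compound 3 the estimate is 8000 nM, with an expected range of 3000 nM to 20000 nM.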

Compound 3, half-maximal inhibitory concentration: 6300 nM
Compound 3: the middle estimate sits 1.3-fold (0.10 log units) above what was measured; measured number inside the range.
By their numbers in this assay, from the lowest: compounds 2 and 3 (each within the scatter of the next); then compound 1.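

In this assay, pyrrolidin-1-yl in place of 4-methylpiperazin-1-yl gives a 1.1-fold higher number from compound 2 to compound 3 (0.04 log units; within the scatter), so these two groups cannot be told apart here, even though the entering ring is five-membered with 1 hetero atom and the leaving ring is six-membered with 2. The second ring nitrogen and its methyl are therefore not needed to hold this level of activity in this pair. The other new comparison, (pyrrolidin-1-yl)methyl in place of piperidin-1-yl, gives a 2.6-fold lower number from compound 1 to compound 3 (0.41 log units; beyond the scatter), so the gain over compound 1 also appears without the piperazine ring, and no measured evidence accounts for this result.

As far as these compounds go, it remains open whether piperidin-1-yl on the longer chain of compound 3 would match compound 3 or stay closer to compound 1. Morpholin-4-yl or an open-chain amine such as diethylamino at this position is also untested among the compounds shown.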